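Compound 4: one stereocentre changed in an inactive series

The compounds below may be only part of what the source reports. "The series", "measured", "known", "first", "only" and "open" are said of these compounds alone.

Measured in a functional assay on CCRF-HSB-2 cells (Homo sapiens) for antiproliferative activity; on this read-out lower numbers stand for stronger inhibition and higher numbers for weaker inhibition:
- compound 1 `Cc1cn([C@@H]2S[C@H](CO)[C@@H](O)[C@@H]2O)c(=O)[nH]c1=O`: > 100 ug/mL
- compound 2 `O=c1[nH]c(=O)n([C@@H]2S[C@H](CO)[C@@H](O)[C@@H]2O)cc1I`: > 100 ug/mL
- compound 3 `O=c1[nH]c(=O)n([C@H]2S[C@H](CO)[C@@H](O)[C@@H]2O)cc1/C=C/Cl`: > 100 ug/mL

All three entries are limits and not numbers. Compound 3 stands at the limit of > 100 ug/mL and has no number of its own. It shares that position with the rest of the series (the limit of > 100 ug/mL in this assay, at which 3 of the 3 values shown sit).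

Compound 4 `O=c1[nH]c(=O)n([C@@H]2S[C@H](CO)[C@@H](O)[C@@H]2O)cc1/C=C/Cl` differs from compound 3 by one change (the two compounds have the same atoms and bonds and differ only in configuration as drawn: 1 of 5 stereo elements differ; a stereocentre at a saturated ring carbon is drawn S in compound 3 and R in compound 4) in the drawn configuration.

For the measured compounds named here, the only measured step (a step that the two limits leave unreadable from compound 1 to compound 2) is of another kind, iodo in place of methyl on an aromatic carbon, and gives no size to carry over. Going by the values given here, no measured step covers a change of configuration. The expectation therefore rests only on the shared limit (the limit of > 100 ug/mL in this assay, at which 3 of the 3 values shown sit), and no step beyond the scatter is expected in this assay. A readable value could only lie toward stronger inhibition.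

The expected step is small (a number no higher from compound 3 to compound 4 (the limit leaves the size open)) and remains an estimate. Compound 4 is estimated at 100 ug/mL, with an expected range from 30 ug/mL to 200 ug/mL.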

Compound 4, half-maximal inhibitory concentration: > 100 ug/mL
Compound 4: a limit, no number (the forecaster's own chance of this, stated with the estimate: 75%); the middle value sits exactly at the limit.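

In this assay compound 4 gives > 100 ug/mL, a limit and not a number. For the compounds shown here, no step from compound 1, compound 2 or compound 3 to compound 4 can be read. The compounds shown leave open whether the configuration at the saturated ring carbon or the group on the aromatic carbon has any bearing on inhibition.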